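This account rests on a few compounds, and the source may have more. Where it says the series, first, only, none or still open, it means among the compounds named here.

Measured so far in a functional assay on HepG2 cells (Homo sapiens) for cytotoxicity, read by MTT assay, with a stated time of 72 h; a higher number here means a weaker inhibitor, a lower number a stronger inhibitor:
compound 1 `O=C(Nc1ccc(Oc2ccnc3[nH]ccc23)c(F)c1)c1nn(-c2ccc(Br)cc2F)ccc1=O` gives 56500 nM
compound 2 `O=C(Nc1ccc(Oc2ccnc3[nH]ccc23)c(F)c1)c1nn(-c2ccc(Cl)c(F)c2)ccc1=O` gives 9610 nM
compound 3 `Cn1ccc2c(Oc3ccc(NC(=O)c4nn(-c5ccc(Br)cc5F)ccc4=O)cc3)ccnc21` gives 31200 nM

Compound 1 and compound 2 share one core and differ in a single place: 4-chloro-3-fluorophenyl in place of 4-bromo-2-fluorophenyl on an aromatic nitrogen The step that goes with this change is a 5.9-fold lower number from compound 1 to compound 2 (0.77 log units; beyond the scatter). Compound 3 carries a different core; the difference between the core of compound 1 and the core of compound 3 is not broken down here. In this assay compound 3 stands near compound 1, the gap between those two being within the scatter, while compound 2 lies beyond the scatter from both.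

Compound 4 `Cn1ccc2c(Oc3ccc(NC(=O)c4nn(-c5ccc(Cl)c(F)c5)ccc4=O)cc3)ccnc21` has not yet been measured in this assay. It differs from compound 3 in one place: 4-chloro-3-fluorophenyl in place of 4-bromo-2-fluorophenyl on an aromatic nitrogen This is the same change as that from compound 1 to compound 2, now made on the core of compound 3; the place is described in the same words in both cases. The change has been seen only once, so the expectation rests on that single measured step. Compound 4 is expected to show a step of about a 5.2-fold lower number from compound 3 to compound 4 (0.72 log units; beyond the scatter), in line with the measured 5.9-fold lower number from compound 1 to compound 2 (0.77 log units; beyond the scatter), the band being widened to allow for the untested core. The estimate for compound 4 in this assay is 6000 nM, with a range from 2500 nM to 15000 nM.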

Compound 4, half-maximal inhibitory concentration: > 60000 nM
Compound 4: only a limit was reported (the forecaster's own chance of this, stated with the estimate: 5%); at least 10-fold (1.00 log units) between middle value and limit.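

In this assay compound 4 gives > 60000 nM, which is a limit of the assay and not a number. Putting 4-chloro-3-fluorophenyl in place of 4-bromo-2-fluorophenyl on the aromatic nitrogen gives an at least 1.9-fold higher number from compound 3 to compound 4 (0.28 log units; that floor lies within the scatter), so the lower number seen on the core of compound 1 does not carry over to the core of compound 3: the same change on two cores in this assay, a 5.9-fold lower number (0.77 log units; beyond the scatter) from compound 1 to compound 2 and an at least 1.9-fold higher number (0.28 log units; that floor lies within the scatter) from compound 3 to compound 4, at least 11-fold (1.05 log units) apart, beyond the scatter of two such steps. This shows that the outcome of the change depends on the core in this pair of pairs, but it does not show the true size of the step on the core of compound 3, nor any rule for other cores, as compound 4 has only a limit: the limit of > 60000 nM in this assay, at which 1 of the 4 values shown sits.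

As far as these compounds go, it remains open which feature separating the core of compound 1 from the core of compound 3 goes with the difference between the two steps. Also open, from the compounds shown here alone, is how a phenyl group bearing an amine or a carboxylic acid would behave on the aromatic nitrogen of either core.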